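The source may hold more compounds than are shown below. What is called first, only, known or untested is meant among the compounds shown, and "the series" means these compounds.

Compound 1, `CNc1nc(N)c2sc(-c3ccc(C(F)(F)F)cc3)cc2n1`: in a physicochemical assay for solubility, at pH 2 (a higher number here means a more soluble compound, a lower number a less soluble compound), compound 1 gives > 100 ug/mL, which is a limit of the assay and not a number.
Compound 2, `CNc1nc(NC2CC2)c2sc(-c3ccc(C(F)(F)F)cc3)cc2n1`: in this assay compound 2 gives 120 ug/mL.
Compound 3, `CNc1nc(Nc2cccc(C(N)=O)c2)c2sc(-c3ccc(C(F)(F)F)cc3)cc2n1`: in this assay compound 3 gives 85 ug/mL.

Compound 3 holds the lowest of the two numbers shown; its nearest neighbour is compound 2, with a 1.4-fold lower number from compound 2 to compound 3 (0.15 log units; within the scatter). The step from the parent is an at least 1.1-fold lower number from compound 1 to compound 3 (0.07 log units; that floor lies within the scatter), while a step that the limit leaves unreadable from compound 1 to compound 2; the limit of > 100 ug/mL in this assay, at which 1 of the 3 values shown sits, sets the floor of what can be said there.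

Compound 4, `CNc1nc(Nc2cccc(S(C)(=O)=O)c2)c2sc(-c3ccc(C(F)(F)F)cc3)cc2n1`, has not been measured in this assay. It differs from compound 3 in one place: methylsulfonyl in place of carbamoyl on an aromatic carbon. Among the measured compounds shown here, none of the measured steps alters a substituent on that phenyl ring; the two steps that bear on it at all are those placing the 3-carbamoylphenyl on the nitrogen, an at least 1.1-fold lower number from compound 1 to compound 3 (0.07 log units; that floor lies within the scatter) and a 1.4-fold lower number from compound 2 to compound 3 (0.15 log units; within the scatter), and both stayed within the scatter. On that basis no step beyond the scatter is expected, so the expected step is a 1.1-fold lower number from compound 3 to compound 4 (0.03 log units; within the scatter). Compound 4 is therefore estimated at 80 ug/mL in this assay, with a range from 40 ug/mL to 160 ug/mL.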

Compound 4, solubility: < 5 ug/mL
Compound 4: no number, only a limit; the forecaster's own chance of this, stated with the estimate: 10%; middle value at least 16-fold (1.20 log units) from the limit.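

The number for compound 4 in this assay is a limit of the assay and not a number, so every step to it gives only a floor: the limit of < 5 ug/mL in this assay, at which 1 of the 4 values shown sits.

Exchanging carbamoyl for methylsulfonyl, on an aromatic carbon meta to a large group, gives an at least 17-fold lower number from compound 3 to compound 4 (1.23 log units; beyond the scatter), the first step in this series shown to lie beyond the scatter. With 3-(methylsulfonyl)phenyl on the nitrogen, the steps are an at least 24-fold lower number from compound 2 to compound 4 (1.38 log units; beyond the scatter) and an at least 20-fold lower number from compound 1 to compound 4 (1.30 log units; beyond the scatter), whereas the steps that placed 3-carbamoylphenyl there stayed within the scatter, so among these compounds a phenyl on that nitrogen does not by itself bring a large step, and the size of the step follows the group carried on that ring.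

On these data alone, how far compound 4 lies past its limit stays open, and a single exchange cannot separate the loss of the amide hydrogen from the arrival of the sulfonyl. The compounds shown also leave open where a nitrile, a carboxylic acid, an amine or a methylated amide on that ring would fall in this assay, and whether methylsulfonyl at another place on the ring would give a step of the same size.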